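The source may hold more compounds than are shown below. What is called first, only, known or untested is meant among the compounds shown, and "the series" means these compounds.

Measured compounds in an ADME assay on MRC5 cells (Homo sapiens) for cytotoxicity, read by fluorescence, with a stated time of 72 h; a higher number here means a weaker inhibitor, a lower number a stronger inhibitor:

compound 1, `O=[N+]([O-])c1cn2c(n1)OC(COc1ccc(-c3ccc(C(F)(F)F)cc3)cc1)C2`: > 64000 nM
compound 2, `O=[N+]([O-])c1cn2c(n1)OC(COc1ccc(-c3ccc(OC(F)(F)F)cc3)cc1)C2`: > 64000 nM
compound 3, `O=[N+]([O-])c1cn2c(n1)OC(COc1ccc(-c3ccc(C(F)(F)F)cc3)cn1)C2`: 45000 nM

The values of compound 1 and compound 2 are each a limit of this assay, not a number. Among the compounds with values here, compound 3 gives the only number in the set. Compound 1 and compound 2 share a core; the difference between them is trifluoromethoxy in place of trifluoromethyl on an aromatic carbon. The step from compound 1 to compound 2 is a step that the two limits leave unreadable from compound 1 to compound 2, and this is because of the limit of > 64000 nM in this assay, at which 2 of the 3 values shown sit.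

Compound 4, `O=[N+]([O-])c1cn2c(n1)OC(COc1ccc(-c3ccc(OC(F)(F)F)cc3)cn1)C2`, has not yet been measured in this assay. The difference between compound 3 and compound 4 is trifluoromethoxy in place of trifluoromethyl on an aromatic carbon. It is the same change as that from compound 1 to compound 2, made on the same place as described for both pairs. How the core of compound 3 differs from the core of compound 1 is not broken down here.

Since the earlier step of this change left no readable size, there is nothing to carry over. The step from compound 3 to compound 4 is expected to be a 1.3-fold higher number from compound 3 to compound 4 (0.12 log units; within the scatter), resting only on compound 3 giving 45000 nM. Compound 4 is therefore estimated at 60000 nM, with a range from 30000 nM to 128000 nM.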

Compound 4, half-maximal inhibitory concentration: 47000 nM
Estimate against measurement, compound 4: 1.3-fold (0.11 log units) above; the range from low to high includes it.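

In this assay, trifluoromethoxy in place of trifluoromethyl gives a 1.0-fold higher number from compound 3 to compound 4 (0.02 log units; within the scatter) and so, on this core, the change stays within the scatter. On the core of compound 1 the same change gives a step that cannot be read, as both values of that pair are limits and not numbers, and no comparison of sizes between the two cores is possible because of this: the limit of > 64000 nM in this assay, at which 2 of the 4 values shown sit. The change therefore has a readable size on one core only, which shows how it stands there but does not show that it carries from one core to another, or that the two steps agree.

Open, as far as these compounds go, is whether the change would give the same size on a further core where both members of the pair give numbers in this assay. Also open, from the compounds shown here alone, is what a group of another kind, such as an amine, a carboxylic acid or a longer chain, would give on the same aromatic carbon in place of trifluoromethyl.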